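This account rests on a few compounds, and the source may have more. Where it says the series, first, only, none or still open, it means among the compounds named here.

Measured so far:
compound 1 `CN1CCCC1CCn1nc(Cc2ccc(Cl)cc2)c2ccccc2c1=O` — 316 nM
compound 2 `O=c1c2ccccc2c(Cc2ccc(Cl)cc2)nn1C1CCCN(CCCCc2ccc(OCCCN3CCCCCC3)cc2)CC1` — 158 nM

Both values come from an assay for binding affinity to Alpha-1A adrenergic receptor (Homo sapiens); a lower number here means a stronger inhibitor, a higher number a weaker inhibitor. Compound 1 gives the highest of the two numbers, but compound 2 sits within the usual scatter of it, so no order between the two can be read from these figures.

Compound 3 `CN1CCC(n2nc(Cc3ccc(Cl)cc3)c3ccccc3c2=O)CC1` has not been measured. It differs from compound 1 by 1-methylpiperidin-4-yl in place of 2-(1-methylpyrrolidin-2-yl)ethyl on an aromatic nitrogen. Within the data shown here, no measured pair shows this change, so nothing fixes its size or direction; the expectation is no step beyond the scatter. For compound 3 the estimate in this assay is 300 nM, range 100 nM to 1000 nM, a step of a 1.1-fold lower number from compound 1 to compound 3 (0.02 log units; within the scatter) that is expected to stay within the scatter.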

Compound 3, inhibition constant: 15.9 nM
Compound 3: middle estimate off by 19-fold (1.28 log units), on the high side, and the stated range ends above it.
By their numbers in this assay, from the lowest: compound 3; then compounds 2 and 1 (each within the scatter of the next).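

On the aromatic nitrogen of the shared core, the choice of group has a large effect in this assay: 1-methylpiperidin-4-yl in place of 2-(1-methylpyrrolidin-2-yl)ethyl gives a 20-fold lower number from compound 1 to compound 3 (1.30 log units; beyond the scatter). Among these compounds, the earlier compounds offered no pair differing in one place, so this is the first size and direction available for a change at this position. Nothing at hand bears on the cause of this step.

This one pair changes both the ring and its ethyl link, and the two cannot be told apart. Open, going by these compounds, is how 1-methylpyrrolidin-3-yl or 2-(1-methylpiperidin-4-yl)ethyl on the same nitrogen would compare.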